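Trifluoromethyl in Place of Hydrogen: Cytotoxicity Expectation

The source may report more compounds than this note shows. Statements on the series, on what has been measured and on what is new or still open speak of the compounds shown alone.

Compound 1 `Cc1ccc(-c2nn(-c3ccccc3)cc2CNc2ccccc2)cc1` in an ADME assay on MT4 cells (Homo sapiens) for cytotoxicity, read by MTT assay, with a stated time of 96 h (on this read-out lower numbers stand for higher toxicity in this test and higher numbers for lower toxicity in this test), reaches only the limit > 100000 nM.
Compound 2 `Clc1ccc(NCc2cn(-c3ccccc3)nc2-c2ccc(Cl)cc2)cc1` in this assay likewise gives the limit > 100000 nM.
Compound 3 `FC(F)(F)c1ccc(-c2nn(-c3ccccc3)cc2CNc2ccc(Br)cc2)cc1` in this assay also gives the limit > 100000 nM.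

Compound 1 therefore stands at the limit together with the other two, with no numerical value to rank it against them, a point supported by the limit of > 100000 nM in this assay, at which 3 of the 3 values shown sit. Compound 4 `Cc1ccc(-c2nn(-c3ccccc3)cc2CNc2ccc(C(F)(F)F)cc2)cc1` differs from compound 1 by trifluoromethyl in place of hydrogen on an aromatic carbon. Among the compounds with values here, no measured pair differing in one place is available, so the expectation rests on all three measured compounds sitting at the limit. For compound 4 the expected step is a number no higher from compound 1 to compound 4 (the limit leaves the size open), none beyond the scatter. Compound 4 is thus estimated at 100000 nM, between 50000 nM and 200000 nM, most likely reported as a limit again.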

Compound 4, half-maximal cytotoxic concentration: > 100000 nM
Compound 4: only a limit was reported; the forecaster's own chance of this, stated with the estimate: 85%; the middle value lies on the limit itself.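

Within the data shown here, compound 1 and compound 4 both give only a limit in this assay, so no step between them can be read. The compounds shown leave open whether trifluoromethyl in place of hydrogen changes this read-out at all: the limit of > 100000 nM in this assay, at which 4 of the 4 values shown sit.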